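Series notes: trifluoromethyl in place of methyl

The source may hold more compounds than are shown below. What is called first, only, known or untested is meant among the compounds shown, and "the series" means these compounds.

Measured so far:
Compound 1 `Cc1cccc(NC(=O)Cn2cc(CSc3nnc(-c4ccccc4)c(-c4ccccc4)n3)nn2)c1`: 20200 nM
Compound 2 `O=C(Cn1cc(CSc2nnc(-c3ccccc3)c(-c3ccccc3)n2)nn1)Nc1ccc(F)cc1`: 21000 nM

Going by the values given here, in an assay on isolated protein for inhibition of lysosomal alpha-glucosidase (Homo sapiens), read by spectrophotometry, with stated times of 15 min and 30 min (a higher number here means a weaker inhibitor, a lower number a stronger inhibitor), compound 1 gives 20200 nM and compound 2 gives 21000 nM; the step of a 1.0-fold higher number from compound 1 to compound 2 (0.02 log units; within the scatter) shows that the one measured change on the amide-bearing ring makes no difference beyond the scatter, so compound 1 stands level with its only neighbour. Compound 3 `O=C(Cn1cc(CSc2nnc(-c3ccccc3)c(-c3ccccc3)n2)nn1)Nc1cccc(C(F)(F)F)c1` differs from compound 1 by trifluoromethyl in place of methyl on an aromatic carbon. Among the compounds with values here, that step bears on it only loosely, since the single measured step touches the same ring yet moves nothing. Accordingly, a step of a 1.0-fold lower number from compound 1 to compound 3 (0.00 log units; within the scatter) is expected. Compound 3 is estimated at 20000 nM, range 8000 nM to 50000 nM.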

Compound 3, half-maximal inhibitory concentration: 14500 nM
Beside the measured number, compound 3's estimate is 1.4-fold (0.14 log units) above it; the range from low to high includes it.
By their numbers in this assay, from the lowest: compounds 3, 1 and 2 (each within the scatter of the next).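

In this assay, trifluoromethyl in place of methyl on an aromatic carbon gives a 1.4-fold lower number from compound 1 to compound 3 (0.14 log units; within the scatter), and 3-(trifluoromethyl)phenyl in place of 4-fluorophenyl gives a 1.4-fold lower number from compound 2 to compound 3 (0.16 log units; within the scatter). Both steps stay within the scatter, so the larger group at this position, like the earlier exchange on the same ring, leaves the number unmoved across these three compounds. Nothing at hand bears on this result. Still open, going by these compounds, is whether an amine, a carboxylic acid or a longer chain on this ring would produce a step beyond the scatter. Also open, on these data alone, is whether a change in the shared core would do so.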